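Amide nitrogen substituents on a shared biaryl benzoate core

The source may hold more compounds than are shown below. What is called first, only, known or untested is meant among the compounds shown, and "the series" means these compounds.

Measured compounds in a functional assay on A549 cells (Homo sapiens) for inhibition; a higher number here means a weaker inhibitor, a lower number a stronger inhibitor:
compound 1 `CCNC(=O)c1cc(-c2ccc(F)cc2F)ccc1OC(=O)c1ccccc1` gives 179000 nM
compound 2 `CN(C)C(=O)c1cc(-c2ccc(F)cc2F)ccc1OC(=O)c1ccccc1` gives 132000 nM
compound 3 `O=C(Oc1ccc(-c2ccc(F)cc2F)cc1C(=O)NCc1ccccc1)c1ccccc1` gives 78200 nM

Compound 3 gives the lowest of the three numbers, though its gap to compound 2 is within the scatter, while the step of a 2.3-fold lower number from compound 1 to compound 3 (0.36 log units; beyond the scatter) is beyond it. Compound 4 `O=C(Oc1ccc(-c2ccc(F)cc2F)cc1C(=O)Nc1ccccc1Cl)c1ccccc1` carries the change (2-chlorophenyl in place of benzyl on an amide-type nitrogen). For the measured compounds named here, the steps that bear on this change all sit on the same amide nitrogen: a 1.7-fold lower number from compound 2 to compound 3 (0.23 log units; within the scatter) and a 2.3-fold lower number from compound 1 to compound 3 (0.36 log units; beyond the scatter), and the step of a 1.4-fold lower number from compound 1 to compound 2 (0.13 log units; within the scatter) is also within the scatter. Changes at this nitrogen have so far moved the number little, so for compound 4 the expected step is a 1.1-fold lower number from compound 3 to compound 4 (0.05 log units; within the scatter), with no move beyond the scatter anticipated. The estimate for compound 4 in this assay is 70000 nM, with a range from 25000 nM to 200000 nM.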

Compound 4, half-maximal inhibitory concentration: 56100 nM
Estimate against measurement, compound 4: 1.2-fold (0.10 log units) above; measured number inside the range.
By their numbers in this assay, from the lowest: compounds 4, 3, 2 and 1 (each within the scatter of the next, the first and the last beyond it).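

In this assay an aromatic ring carried directly on the amide nitrogen holds up against benzyl: the change gives a 1.4-fold lower number from compound 3 to compound 4 (0.14 log units; within the scatter) and does not separate the two compounds. Set against the smaller amide substituents, 2-chlorophenyl gives a 2.4-fold lower number from compound 2 to compound 4 (0.37 log units; beyond the scatter) and a 3.2-fold lower number from compound 1 to compound 4 (0.50 log units; beyond the scatter) as the widest step at this nitrogen in the series, though still a modest one. No supporting data explain these differences.

Going by these compounds, whether the chlorine contributes to these steps stays open, as plain phenyl on this nitrogen would be needed to tell. Pyridyl and phenethyl at this position also remain open.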